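The compounds below may be only part of what the source reports. "The series", "measured", "known", "first", "only" and "open" are said of these compounds alone.

Values measured in an ADME assay on HepG2 cells (Homo sapiens) for cytotoxicity, in the presence of a further agent that is not named here; on this read-out higher numbers stand for weaker inhibition and lower numbers for stronger inhibition
Compound 1 `Cn1c(Cc2ccccc2)nc(C(=O)NCc2ccccc2)c(O)c1=O` gives > 100000 nM
Compound 2 `Cn1c(Cc2ccccc2C(F)(F)F)nc(C(=O)CCc2ccccc2)c(O)c1=O` gives > 100000 nM
Compound 3 `Cn1c(Cc2ccccc2C(F)(F)F)nc(C(=O)NCc2ccc(F)cc2)c(O)c1=O` gives > 100000 nM

Compound 3 stands at > 100000 nM and this is a limit of the assay, not a number. The two other values are limits too, so the whole picture is the limit of > 100000 nM in this assay, at which 3 of the 3 values shown sit, and nothing ranks one compound against another.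

Compound 4 `Cn1c(Cc2ccccc2C(F)(F)F)nc(C(=O)NCc2ccccc2)c(O)c1=O` is the same as compound 3 apart from one change: hydrogen in place of fluoro on an aromatic carbon (hydrogen in place of fluoro on an aromatic carbon, para to a large group, so that (4-fluorobenzyl)amino becomes benzylamino).

Within the data shown here, only one measured step bears on this (a step that the two limits leave unreadable from compound 2 to compound 3) and it offers no size to carry over, as both of its ends are limits. Compound 1 already carries benzylamino, and its > 100000 nM is likewise a limit.

In this assay no step beyond the scatter is therefore expected, and no direction can be given. The expected step is a number no higher from compound 3 to compound 4 (the limit leaves the size open) and it remains an estimate resting on limits alone. For compound 4 the estimated value is 100000 nM with an expected range from 50000 nM to 200000 nM and the assay is expected to report a limit once more.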

Compound 4, half-maximal inhibitory concentration: > 100000 nM
Compound 4 ended at the assay's limit (the forecaster's own chance of this, stated with the estimate: 85%); the middle value lies on the limit itself.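

Among these compounds, no step from compound 1, compound 2 or compound 3 to compound 4 can be read, as all four compounds sit at the same limit: the limit of > 100000 nM in this assay, at which 4 of the 4 values shown sit. The compounds shown leave open at what concentration any of them would reach half-maximal inhibition, and whether hydrogen in place of fluoro or trifluoromethyl in place of hydrogen changes the read-out at all.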